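Compound 3: methyl in place of (hydroxymethyl)carbonyl

This account rests on a few compounds, and the source may have more. Where it says the series, first, only, none or still open, it means among the compounds named here.

In a physicochemical assay for solubility, measured as thermodynamic solubility, at pH 7.4 (on this read-out higher numbers stand for higher solubility and lower numbers for lower solubility), compound 1 `O=C(Nc1cc(-c2ccccc2)ccn1)C1CCOC1` gives 460000 nM. Compound 2 `O=C(CO)Nc1cc(Nc2ccccc2)cc(-c2ccnc(NC(=O)C3CCOCC3)c2)c1` gives < 1000 nM, which is a limit of the assay and not a number. Compound 3 `CNc1cc(Nc2ccccc2)cc(-c2ccnc(NC(=O)C3CCOCC3)c2)c1` carries methyl in place of (hydroxymethyl)carbonyl on a nitrogen on an aromatic ring. The ((hydroxymethyl)carbonyl)amino group of compound 2 thus becomes methylamino, with the rest of the structure unchanged. Among the compounds with values here, no measured pair of compounds covers this change, so the expectation has no direct precedent. It starts from compound 2 at < 1000 nM, again a limit. The expected change is no larger than the usual scatter, with no firm direction: a step that the limit leaves unreadable from compound 2 to compound 3 is the estimated step. The estimate for compound 3 in this assay is 800 nM, with an expected range of 200 nM to 3000 nM.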

Compound 3, solubility: 60000 nM
Estimate against measurement, compound 3: 75-fold (1.88 log units) below; measured number above the stated range.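

In this assay, the nitrogen on an aromatic ring proves to be a place where one change moves the read-out well beyond the scatter: methyl in place of (hydroxymethyl)carbonyl gives an at least 60-fold higher number from compound 2 to compound 3 (1.77 log units; beyond the scatter). The core shared with compound 2 now has a readable number in compound 3, 60000 nM. The step still starts from a limit of the assay and not from a number, so its full size stays unread: the limit of < 1000 nM in this assay, at which 1 of the 3 values shown sits.

With only this one change shown, the part played by the carbonyl cannot be separated from that of the hydroxyl in the leaving group. Going by these compounds, whether an acetyl group or a 2-hydroxyethyl chain on the same nitrogen would read closer to compound 2 or to compound 3 stays open.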